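Bromo for Chloro: What to Expect of Compound 4

The source may report more compounds than this note shows. Statements on the series, on what has been measured and on what is new or still open speak of the compounds shown alone.

Compound 1 `O=C(CSc1nc(Nc2ccccc2)c2ccccc2n1)Nc1ccccc1Cl`: 14600 nM
Compound 2 `O=C(CSc1nc(Nc2ccccc2)c2ccccc2n1)Nc1ccccc1Br`: 19800 nM
Compound 3 `O=C(CSc1nc(Nc2ccccc2)c2ccccc2n1)Nc1ccc(Cl)cc1`: 12900 nM

These three compounds share one core and differ only in the group on the amide nitrogen; all were tested in a functional assay on PC-3 cells (Homo sapiens) for inhibition, read by MTT assay, with a stated time of 72 h; a lower number here means a stronger inhibitor, a higher number a weaker inhibitor. Compound 4 `O=C(CSc1nc(Nc2ccccc2)c2ccccc2n1)Nc1ccc(Br)cc1` has not yet been measured. The change leading to it is bromo in place of chloro on an aromatic carbon. The same kind of change has been made once already, as bromo in place of chloro on an aromatic carbon, and there it gave a 1.4-fold higher number from compound 1 to compound 2 (0.13 log units; within the scatter). The two places are not identical: in compound 1 the halogen sits ortho to a large group, in compound 3 para to a large group, so this is the same kind of change rather than the same change. The cores of compound 1 and compound 3 differ by 4-chlorophenyl in place of 2-chlorophenyl on an amide-type nitrogen, with a 1.1-fold lower number from compound 1 to compound 3 (0.05 log units; within the scatter). Between compound 2 and compound 3 the step is a 1.5-fold lower number from compound 2 to compound 3 (0.19 log units; within the scatter).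

For compound 4 a step of a 1.2-fold higher number from compound 3 to compound 4 (0.09 log units; within the scatter) is expected, resting on the earlier step of a 1.4-fold higher number from compound 1 to compound 2 (0.13 log units; within the scatter), which stayed within the scatter. Compound 4 is therefore estimated to give 16000 nM, most likely between 8000 nM and 32000 nM.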

Compound 4, half-maximal inhibitory concentration: 8450 nM
Estimate against measurement, compound 4: 1.9-fold (0.28 log units) above, within the range that was stated.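

In this assay, bromo in place of chloro gives a 1.5-fold lower number from compound 3 to compound 4 (0.18 log units; within the scatter), and this step does not differ measurably from the one made earlier on the core of compound 1: the same change on two cores in this assay, a 1.4-fold higher number (0.13 log units; within the scatter) from compound 1 to compound 2 and a 1.5-fold lower number (0.18 log units; within the scatter) from compound 3 to compound 4, 2.1-fold (0.32 log units) apart, within the scatter of two such steps. This shows that on these two cores the change stays too small to read, but it does not establish a shared direction, since one step is printed as higher and the other as lower, and both lie within the scatter. Among the remaining steps, a 1.7-fold lower number from compound 1 to compound 4 (0.24 log units; within the scatter) also stays within the scatter, while a 2.3-fold lower number from compound 2 to compound 4 (0.37 log units; beyond the scatter) is beyond it, though only modestly, so 4-bromophenyl in place of 2-bromophenyl is the only step here that can be told apart from noise.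

The compounds shown leave open what other groups in place of the halogen, such as fluoro, methoxy or an amine, would do to the number. They also leave open whether that single modest step would hold up on repeat measurement or in other cells.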